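The source may report more compounds than this note shows. Statements on the series, on what has been measured and on what is new or still open speak of the compounds shown alone.

Two compounds of the series carry a number in a functional assay (blood) for inhibition, with Homo sapiens as the target; on this read-out higher numbers stand for weaker inhibition and lower numbers for stronger inhibition. Compound 1 `C/C(=N\OCCSc1nnnn1C)c1ccc(Sc2cc(F)cc(C3CCOCC3)c2)cc1` gives 120 nM in this assay, the higher of the two numbers; compound 2 `COC1(c2csc(Sc3ccc4c(c3)OCC/C4=N\OCC#N)c2)CCOCC1` gives 60 nM in this assay, and the gap between the two lies within the usual scatter of repeated measurements, so no order can be read from them. Within the data shown here, no pairing between measured compounds differs in a single place, so no step size is established.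

Compound 3 `C/C(=N\O)c1ccc(Sc2cc(F)cc(C3CCOCC3)c2)cc1` has not been measured in this assay. It is derived from compound 1 by the change (hydrogen in place of 2-((1-methyl-1H-tetrazol-5-yl)sulfanyl)ethyl on an oxygen). The 2-((1-methyl-1H-tetrazol-5-yl)sulfanyl)ethyl group is replaced on the oxygen by hydrogen, leaving a hydroxy where the longer chain stood.

Among the measured compounds shown here, with no measured step of this kind available, the direction has to be taken as an expectation only. The loss of the nine-heavy-atom chain is expected to weaken inhibition somewhat, which is the step written as a 2.5-fold higher number from compound 1 to compound 3 (0.40 log units; beyond the scatter). Compound 3 is accordingly expected to give about 300 nM in this assay, within a range from 100 nM to 1200 nM. For the measured compounds named here, the range is wide; no reference step exists that could narrow it.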

Compound 3, half-maximal inhibitory concentration: 80 nM
For compound 3 the middle estimate is 3.8-fold (0.57 log units) above the measured one, outside the stated range (below it).
By their numbers in this assay, from the lowest: compounds 2, 3 and 1 (each within the scatter of the next).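

In this assay, among these compounds, the first step at this position, a 1.5-fold lower number from compound 1 to compound 3 (0.18 log units; within the scatter), lies within the scatter, so exchanging 2-((1-methyl-1H-tetrazol-5-yl)sulfanyl)ethyl for hydrogen on the oxygen bonded to the double-bonded nitrogen gives no readable difference. On the core of compound 1, the series thus tolerates the loss of all 9 heavy atoms of that chain, including its five-membered aromatic ring with 4 hetero atoms, and the hydroxy of compound 3 holds a number indistinguishable from that of the longer 2-((1-methyl-1H-tetrazol-5-yl)sulfanyl)ethoxy. No supporting data accompany this pair, so the result stands as an observation on these two compounds alone.

Going by these compounds, with one step at this position, it remains open whether a small group such as methyl, a simple ethyl chain, or a chain ending in an amine or a carboxylic acid would also stay within the scatter of compound 3 on the same oxygen. On these data alone, compound 2 differs from compound 1 and compound 3 in more than one place, so the effect of the same exchange on its core also remains open.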